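Acyl nucleoside esters against mitochondrial thymidine kinase 2

The source may report more compounds than this note shows. Statements on the series, on what has been measured and on what is new or still open speak of the compounds shown alone.

Compound 1 `CCCCCCCC(=O)O[C@H]1[C@H](O)[C@@H](CO)O[C@H]1n1cc(C)c(=O)[nH]c1=O`: 120000 nM
Compound 2 `CCCCCCCC(=O)O[C@H]1[C@H](O)[C@@H](CO)O[C@H]1n1cnc2c(=O)[nH]c(N)nc21`: > 500000 nM

In an assay on isolated protein for inhibition of thymidine kinase 2, mitochondrial (Homo sapiens) (a higher number here means a weaker inhibitor, a lower number a stronger inhibitor), compound 1 gives 120000 nM. Compound 2 gives only a limit in this assay, > 500000 nM, sitting at the limit of > 500000 nM in this assay, at which 1 of the 2 values shown sits, so no number is known for it. Compound 3 `CCCCCCCC(=O)Nc1nc2c(ncn2[C@@H]2O[C@H](CO)[C@@H](O)[C@@H]2OC(=O)CCCCCCC)c(=O)[nH]1` differs from compound 2 by heptylcarbonyl in place of hydrogen on a nitrogen on an aromatic ring, amino to (heptylcarbonyl)amino. Within the data shown here, no measured step links these two; with compound 2 already at the limit, the step from compound 2 to compound 3 is expected to show nothing beyond the scatter, a step that the limit leaves unreadable from compound 2 to compound 3. Compound 3 is expected at 700000 nM, range 200000 nM to 3000000 nM, most likely reported again as a limit.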

Compound 3, half-maximal inhibitory concentration: > 500000 nM
Compound 3: no number, only a limit; the forecaster's own chance of this, stated with the estimate: 80%; the middle value lies beyond the limit too.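

In this assay compound 2 and compound 3 both give only limits, so the step between them cannot be read. The compounds shown leave open whether heptylcarbonyl in place of hydrogen on a nitrogen on an aromatic ring changes inhibition at all.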